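From thiophen-2-yl to thiophen-3-yl on compound 2

The compounds below may be only part of what the source reports. "The series", "measured", "known", "first", "only" and "open" are said of these compounds alone.

Compound 1 `Cc1ccc(-c2cc(-c3ccoc3)cc(-c3ccsc3)n2)cc1` measures 13000 nM
Compound 2 `Clc1ccc(-c2cc(-c3ccoc3)cc(-c3cccs3)n2)cc1` measures 21100 nM

In a functional assay on DU-145 cells (Homo sapiens) for cytotoxicity, in the presence of a further agent that is not named here (on this read-out higher numbers stand for weaker inhibition and lower numbers for stronger inhibition), compound 2 gives 21100 nM and compound 1 gives 13000 nM and these two numbers lie within the usual scatter of each other, so they cannot be told apart.

Compound 3 `Clc1ccc(-c2cc(-c3ccoc3)cc(-c3ccsc3)n2)cc1` has not been measured yet. It has the same atoms as compound 2, joined differently, with thiophen-3-yl in place of thiophen-2-yl on an aromatic carbon next to the ring nitrogen thiophen-3-yl in place of thiophen-2-yl on an aromatic carbon and nothing else altered.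

For the measured compounds named here, no measured pair shows this kind of change, so the data offer no direct guide. The expected size is a small step of a 1.3-fold lower number from compound 2 to compound 3 (0.12 log units; within the scatter) that would stay within the scatter. Compound 3 is estimated at 16000 nM with an expected range of 7000 nM to 35000 nM as the likely outcome.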

Compound 3, half-maximal inhibitory concentration: 37600 nM
Beside the measured number, compound 3's estimate is 2.4-fold (0.37 log units) below it; measured number outside the range, above it.
By their numbers in this assay, from the lowest: compounds 1, 2 and 3 (each within the scatter of the next, the first and the last beyond it).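

In this assay, thiophen-3-yl in place of thiophen-2-yl on the aromatic carbon next to the ring nitrogen gives a 1.8-fold higher number from compound 2 to compound 3 (0.25 log units; within the scatter), so these two thiophene attachments cannot be told apart at this position. Compound 1 and compound 2 differ in two places, but compound 3 differs from compound 1 in only one: with thiophen-3-yl kept, chloro in place of methyl gives a 2.9-fold higher number from compound 1 to compound 3 (0.46 log units; beyond the scatter), a modest weakening of inhibition. Nothing available explains either step.

This single pair leaves open whether chloro and methyl would separate in the same way with thiophen-2-yl in place. On these data alone, it is also open whether an amine or a longer chain in place of the thiophene would shift the number beyond the scatter.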